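The source may report more compounds than this note shows. Statements on the series, on what has been measured and on what is new or still open speak of the compounds shown alone.

Measured compounds:
compound 1 `COc1ccc(C(=O)c2cnc(/N=C(\N)Nc3ccc(F)cc3)nc2)c(O)c1`: 18000 nM
compound 2 `COc1ccc(N/C(N)=N/c2ncc(C(=O)c3ccccc3O)cn2)cc1`: 27000 nM

In an assay on HEK-Blue hTLR4 cells for inhibition of Toll-like receptor 4 (Homo sapiens) (on this read-out lower numbers stand for stronger inhibition and higher numbers for weaker inhibition), compound 1 gives 18000 nM and compound 2 gives 27000 nM; the two numbers sit within the usual scatter of each other, so neither can be called the more potent. Among the compounds with values here, no pair of measured compounds differs in one place only, so no measured step is available.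

Compound 3 `N/C(=N\c1ncc(C(=O)c2cc(Cl)ccc2O)cn1)Nc1ccc(F)cc1` is not yet measured. It differs from compound 1 in one place: 5-chloro-2-hydroxyphenyl in place of 2-hydroxy-4-methoxyphenyl on a carbonyl carbon. Within the data shown here, with no measured step to lean on, a change of no more than the scatter is expected, in either direction, giving compound 3 an estimated 15000 nM (range 5000 nM to 45000 nM), a step of a 1.2-fold lower number from compound 1 to compound 3 (0.08 log units; within the scatter) expected.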

Compound 3, half-maximal inhibitory concentration: 40000 nM
Compound 3: middle estimate off by 2.7-fold (0.43 log units), on the low side; low and high end bracket the measured number.
By their numbers in this assay, from the lowest: compounds 1, 2 and 3 (each within the scatter of the next, the first and the last beyond it).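

In this assay, within the data shown here, the swap of 2-hydroxy-4-methoxyphenyl for 5-chloro-2-hydroxyphenyl on the carbonyl carbon gives a 2.2-fold higher number from compound 1 to compound 3 (0.35 log units; beyond the scatter) as the only one-place step available, so the aryl group at this position is not indifferent to change, though the step is modest. The swap removes the methoxy group and brings in chlorine at once, so their separate contributions cannot be told apart. Nothing at hand accounts for the shift.

Going by these compounds, whether removing the methoxy group or adding chlorine drives the step remains open. Also open, on these data alone, is how this position would take an amine or a carboxylic acid on the same ring.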